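The source may report more compounds than this note shows. Statements on the series, on what has been measured and on what is new or still open speak of the compounds shown alone.

Measured in a functional assay on A549 cells (Homo sapiens) for antiproliferative activity, read by CCK-8 assay, with a stated time of 48 h; a lower number here means a stronger inhibitor, a higher number a weaker inhibitor:
compound 1 `O=c1c2ccccc2[se]n1-c1nnc(-c2ccc(Br)cc2)s1`: 39100 nM
compound 2 `O=c1c2ccccc2[se]n1-c1nnc(-c2cccc([N+](=O)[O-])c2)s1`: 16100 nM

Compound 1 carries the higher of the two numbers; compound 2 sits below it, a gap beyond the usual scatter. Compound 3 `O=c1c2ccccc2[se]n1-c1nnc(-c2ccc(Cl)cc2)s1` is not yet measured. It differs from compound 1 by chloro in place of bromo on an aromatic carbon. Going by the values given here, no pair of measured compounds isolates this exchange, so nothing indicates its size. The expected step of a 1.1-fold lower number from compound 1 to compound 3 (0.04 log units; within the scatter) is none beyond the scatter, in no particular direction. Compound 3 is therefore estimated at 36000 nM, with a range from 15000 nM to 85000 nM in this assay.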

Compound 3, half-maximal inhibitory concentration: 10400 nM
The estimate for compound 3 lay 3.5-fold (0.54 log units) above the measured number; the whole stated range lies above it.
By their numbers in this assay, from the lowest: compounds 3 and 2 (each within the scatter of the next); then compound 1.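

The change from 4-bromophenyl to 4-chlorophenyl in this assay gives a 3.8-fold lower number from compound 1 to compound 3 (0.58 log units; beyond the scatter) and is thus a modest step beyond the scatter. Going by these compounds alone, this is the first pair that isolates a single change, and it shows that this aromatic carbon does not treat the two halogens alike. No data on hand bear on the origin of the step.

Fluoro, methoxy or an amine on the same aromatic carbon remain open. So does whether the chloro-for-bromo step holds elsewhere on the ring.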